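The source may report more compounds than this note shows. Statements on the series, on what has been measured and on what is new or still open speak of the compounds shown alone.

Working notes on the series. Three compounds share a core and differ in their ester groups. Compound 1 `CCCCC(=O)OC[C@H]1O[C@@H](n2cnc3c(OC)ncnc32)[C@@H](OC(=O)CCCC)[C@@H]1OC(=O)CCCC` gives 21000 nM in a physicochemical assay for solubility, in phosphate buffer; a higher number here means a more soluble compound, a lower number a less soluble compound. Compound 2 `COc1ncnc2c1ncn2[C@@H]1O[C@H](COC(=O)C(C)C)[C@@H](OC(=O)C(C)C)[C@@H]1OC(=O)C(C)C` gives 141000 nM in this assay, and compound 3 `CCCCCC(=O)O[C@H]1[C@H](OC(=O)CCCCC)[C@@H](CO)O[C@H]1n1cnc2c(OC)ncnc21` gives 140000 nM in this assay. Compound 2 holds the highest of the three numbers; its reading and that of compound 3 lie within the scatter of each other, while the number of compound 1 lies beyond the scatter below it.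

Compound 4 `COc1ncnc2c1ncn2[C@@H]1O[C@H](CO)[C@@H](OC(=O)C(C)C)[C@@H]1OC(=O)C(C)C` has not yet been measured in this assay. It differs from compound 2 by hydrogen in place of isopropylcarbonyl on an oxygen on a saturated carbon. Among the compounds with values here, no measured pair shows this change on its own, so the size of the step cannot be read off directly. The values of compounds 1 and 3 show that a compound carrying a free hydroxymethyl group sits at the higher end of the numbers seen here. The step from compound 2 to compound 4 is expected to be a modest rise in solubility, a 2.1-fold higher number from compound 2 to compound 4 (0.33 log units; beyond the scatter), though a result within the scatter would not surprise. Compound 4 is expected to give about 300000 nM in this assay, with a range from 120000 nM to 800000 nM.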

Compound 4, solubility: 3300000 nM
Estimate against measurement, compound 4: 11-fold (1.04 log units) below; the whole stated range lies below it.
By their numbers in this assay, from the lowest: compound 1; then compounds 3 and 2 (each within the scatter of the next); then compound 4.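

Hydrogen in place of isopropylcarbonyl on an oxygen on a saturated carbon, which turns ((isopropylcarbonyl)oxy)methyl into hydroxymethyl, gives a 23-fold higher number from compound 2 to compound 4 (1.37 log units; beyond the scatter) in this assay. Within the data shown here, this is the first change seen on its own, since the three earlier compounds differ from each other in more than one place and could not isolate the effect of any single ester. It shows that this one position alone can carry a large step, well beyond the scatter, with the rest of compound 2 left unchanged. Nothing else shown bears on why the step is this large.

Going by these compounds, it remains open whether the same replacement on either of the two remaining isopropylcarbonyl groups of compound 2 would give a step of similar size, or whether removing more than one of them would add further. Also open, on these data alone, is how the reading at this position would respond to an acetyl ester, a methyl ether, an amine or a carboxylic acid in place of the hydroxymethyl group of compound 4.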